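A few compounds are considered here, and "the series" means these few. Any claim that something is new, unique, unknown or untested is made for them only; others in the source may bear on it.

Two compounds sharing one core were set against an assay on HEK293 cells for positive allosteric modulation of metabotropic glutamate receptor 2 (Rattus norvegicus), read by thallium flux, with a stated time of 2.5 min; a lower number here means that less compound is needed, a higher number that more compound is needed for the effect. The first, compound 1 `COC(=O)c1ccc(OCCCCOc2ccc(C(=O)CC3CCCC3)c(O)c2C)cc1`, came back as "not determined" (no result reported), so no number stands for it. Going by the values given here, compound 2 `COc1ccc(C(=O)O)cc1OCCCCOc1ccc(C(=O)C(C)C)c(O)c1C` is therefore the only compound with a measured value in this assay, where compound 2 gives 116 nM; with nothing else measured, no comparison within the set is possible.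

Compound 3 `COc1ccc(C(=O)O)cc1OCCCCOc1ccc(C(C)=O)c(O)c1C` has not yet been measured. It differs from compound 2 in a single place: methyl in place of isopropyl on a carbonyl carbon. Among the compounds with values here, no step between two measured compounds exists that would show what this exchange does here, so the expectation rests on the single value of compound 2 alone. A modest shift toward a higher number, roughly at the edge of the usual scatter, is expected, written as a 2.6-fold higher number from compound 2 to compound 3 (0.41 log units; beyond the scatter). Compound 3 is accordingly estimated at 300 nM, with a plausible range from 100 nM to 1000 nM.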

Compound 3, half-maximal effective concentration: 1090 nM
Beside the measured number, compound 3's estimate is 3.6-fold (0.56 log units) below it; measured number above the stated range.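

In this assay, going by these compounds alone, the group on the carbonyl carbon turns out to matter: methyl in place of isopropyl gives a 9.4-fold higher number from compound 2 to compound 3 (0.97 log units; beyond the scatter) and is the first step between two measured compounds here. Within the data shown here, the position therefore responds to this exchange, and of these two groups, isopropyl is the one that needs less compound for the effect. Nothing measured alongside these values explains why the number moves in this direction.

With only methyl and isopropyl to compare, two groups cannot show a trend, and compound 1 has no number to add to them. From the compounds shown here alone, it remains open whether an ethyl, a tert-butyl or a cyclopropyl group on the same carbonyl carbon would give a lower or a higher number than isopropyl.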